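This account rests on a few compounds, and the source may have more. Where it says the series, first, only, none or still open, it means among the compounds named here.

Measured so far:
Compound 1, `CN1CCN(CC(=O)NCC(=O)N(C)c2ccc(Cl)cc2C(=O)c2ccccc2Cl)CC1`: 59 mg/kg
Compound 2, `CCC(=O)NCC(=O)N(C)c1ccc(Cl)cc1C(=O)c1ccccc1Cl`: 1.4 mg/kg

Among the measured compounds shown here, in a functional assay on the whole organism for antagonist activity, with Mus musculus as the target (on this read-out lower numbers stand for an effect already at smaller amounts and higher numbers for an effect only at larger amounts of compound), compound 2 stands lowest of the two numbers, and compound 1 is its only neighbour. The new compound 3, `CN(C(=O)CNC(=O)CN)c1ccc(Cl)cc1C(=O)c1ccccc1Cl`, differs from compound 2 by amino in place of methyl on a saturated chain carbon bound to a carbonyl carbon. For the measured compounds named here, the one step that bears on this position is a 42-fold lower number from compound 1 to compound 2 (1.62 log units; beyond the scatter), where a 4-methylpiperazin-1-yl group on the same carbon went with a far higher number than the methyl group. An amino group entering there is therefore expected to raise the number again, though less steeply. The expected step is a 5.7-fold higher number from compound 2 to compound 3 (0.76 log units; beyond the scatter). Compound 3 is thus estimated at 8 mg/kg, within 2.5 mg/kg to 25 mg/kg.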

Compound 3, dose for half-maximal effect: 0.58 mg/kg
Beside the measured number, compound 3's estimate is 14-fold (1.14 log units) above it; the measured number lies below the stated range.
By their numbers in this assay, from the lowest: compound 3; then compound 2; then compound 1.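

In this assay amino on the saturated chain carbon bound to a carbonyl carbon brings a 2.4-fold lower number from compound 2 to compound 3 (0.38 log units; beyond the scatter) and a 100-fold lower number from compound 1 to compound 3 (2.01 log units; beyond the scatter). The earlier pair showed only that methyl gave a lower number than 4-methylpiperazin-1-yl; now a small amino group gives a lower number than either, so a nitrogen on this carbon does not by itself go with a high number. Nothing at hand explains this change. Open, on these data alone, is whether a methylamino group, a dimethylamino group or a longer chain such as aminoethyl would keep the number as low as compound 3 does.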